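This account rests on a few compounds, and the source may have more. Where it says the series, first, only, none or still open, it means among the compounds named here.

Of the compounds shown here, three have been measured in an ADME assay on Vero cells (Chlorocebus sabaeus) for cytotoxicity, read by luminescence, with a stated time of 2 days; a lower number here means that less compound is tolerated, a higher number that more compound is tolerated. Compound 1 `CCc1nc2ccccc2n1CCCCOc1cccc(Cl)c1` gives 22 uM, the highest of the three numbers. Compound 2 `CCc1nc2ccc(C)cc2n1CCCOc1ccc(C)c(Cl)c1` gives 17 uM, which lies within the scatter of compound 1. Compound 3 `CCc1nc2ccc(C)cc2n1CCCOc1ccc(C)c(C)c1` gives 7.3 uM, and its distance from compound 1 is beyond the scatter. Within the data shown here, the only change that can be read as a single step between measured compounds is a 2.3-fold lower number from compound 2 to compound 3 (0.37 log units; beyond the scatter).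

Compound 4 `CCc1nc2ccccc2n1CCCCOc1cccnc1` differs from compound 1 in one place: pyridin-3-yl in place of 3-chlorophenyl on an oxygen on a saturated carbon. Among the measured compounds shown here, no measured step exchanges one whole aromatic ring for another in this way; the step from compound 2 to compound 3 only swaps one group on an aromatic carbon for another, so it does not bear directly on the new change. For the measured compounds named here, with no comparable step to lean on, the expectation for compound 4 is a small shift at most: a 1.4-fold higher number from compound 1 to compound 4 (0.13 log units; within the scatter) is expected, a step that would stay within the scatter. Compound 4 is therefore estimated at 30 uM, with a likely range from 15 uM to 60 uM.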

Compound 4, half-maximal toxic concentration: > 50 uM
Compound 4 gave a limit, no number; the forecaster's own chance of this, stated with the estimate: 10%; at least 1.6-fold (0.22 log units) between middle value and limit.
By their numbers in this assay, from the lowest: compound 3; then compounds 2 and 1 (each within the scatter of the next). At a limit, above all of these: compound 4.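

Among these compounds, the earlier compounds showed only one group on an aromatic carbon being swapped for another, whereas this step exchanges the whole ring on an oxygen on a saturated carbon. In this assay, that exchange, pyridin-3-yl in place of 3-chlorophenyl, gives an at least 2.2-fold higher number from compound 1 to compound 4 (0.35 log units; beyond the scatter). Compound 4 gives > 50 uM, which is a limit of the assay and not a number, and the full size of the step cannot be read because of that limit: the limit of > 50 uM in this assay, at which 1 of the 4 values shown sits.

A plain phenyl ring at this place would help separate the loss of the chlorine from the arrival of the ring nitrogen. Going by these compounds, it also remains open whether pyridin-3-yl would have a similar effect on the rest of compound 2 or compound 3, and how a pyridin-4-yl or pyrimidine ring would compare.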